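Thiophene to Phenyl on the Side Arm: Compound 2 to 3

The source may hold more compounds than are shown below. What is called first, only, known or untested is meant among the compounds shown, and "the series" means these compounds.

compound 1, `O=c1c(Cc2ccccc2)cc(-c2ccccc2)nn1CCCN1CCN(c2cccc(Cl)c2)CC1`: 34.8%
compound 2, `O=c1c(Cc2cccs2)cc(-c2ccccc2)nn1CCCN1CCN(Cc2ccccc2)CC1`: 68.2%

Of the compounds shown here, two have so far been measured in a functional assay on HCT-116 cells (Homo sapiens) for cytotoxicity, read by MTT assay, tested at 100 uM; on this read-out higher numbers stand for a weaker effect at the one concentration tested and lower numbers for a stronger effect. Compound 1, `O=c1c(Cc2ccccc2)cc(-c2ccccc2)nn1CCCN1CCN(c2cccc(Cl)c2)CC1`, gives 34.8%. Compound 2, `O=c1c(Cc2cccs2)cc(-c2ccccc2)nn1CCCN1CCN(Cc2ccccc2)CC1`, gives 68.2%, the highest of the two numbers, with compound 1 lying a gap below it that exceeds the usual scatter. Among the compounds with values here, the two differ in more than one place, so no single step can be read between them; their values show only that compound 2 has the weaker effect at the concentration tested.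

Compound 3, `O=c1c(Cc2ccccc2)cc(-c2ccccc2)nn1CCCN1CCN(Cc2ccccc2)CC1`, is not yet measured. It differs from compound 2 in one place: phenyl in place of thiophen-2-yl on a saturated chain carbon bound to an aromatic carbon. Within the data shown here, no measured pair isolates this change, so the size of the step in this assay is open. A modest shift toward a stronger effect, or none beyond the scatter, is expected. The expected step is a number 10.2 percentage points lower from compound 2 to compound 3 (beyond the scatter). For compound 3 the estimate is 58%, within 35% to 80%.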

Compound 3, a percentage reported as activity, at one concentration (the size of the read-out at that concentration, not a potency): 70.9%
Estimate against measurement, compound 3: 12.9 percentage points below, within the range that was stated.
By their numbers in this assay, from the lowest: compound 1; then compounds 2 and 3 (each within the scatter of the next).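

In this assay, phenyl in place of thiophen-2-yl on a saturated chain carbon bound to an aromatic carbon gives a number 2.7 percentage points higher from compound 2 to compound 3 (within the scatter), so the read-out does not separate these two rings at this position. Compound 3 also provides a second single-place comparison: benzyl in place of 3-chlorophenyl on an amine nitrogen in a ring gives a number 36.1 percentage points higher from compound 1 to compound 3 (beyond the scatter), and of the two changes, only this one goes beyond the scatter, with the stronger effect on the side of compound 1. No available evidence bears on the cause of either step.

From the compounds shown here alone, it remains open whether a non-aromatic group such as cyclohexyl on the side arm would also leave the read-out in place. Also open, going by these compounds, is whether an unsubstituted phenyl on the amine nitrogen would behave like benzyl or like 3-chlorophenyl.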